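This account rests on a few compounds, and the source may have more. Where it says the series, first, only, none or still open, it means among the compounds named here.

Compound 1 (`Cc1ccc(C)n1-c1cccc(COc2ccc3c(c2)OCC3CC(=O)O)c1`) – 3.95
Compound 2 (`Cc1noc(C)c1-c1cccc(COc2ccc3c(c2)OCC3CC(=O)O)c1`) – 1.57
Compound 3 (`Cc1noc(C)c1-c1cc(COc2ccc3c(c2)OCC3CC(=O)O)ccc1Cl`) – 1.96

In a physicochemical assay for lipophilicity, read by HPLC, with a stated time of 24 h, at pH 7.4, tested at 100 uM (on this read-out lower numbers stand for lower lipophilicity and higher numbers for higher lipophilicity), compound 3 gives 1.96 and so stands second of the three, with compound 2 the nearest below it and compound 1 far above it. The next compound is compound 4 (`Cc1noc(C)c1-c1cc(COc2ccc3c(c2)OC[C@H]3CC(=O)O)ccc1Cl`), and its difference from compound 3 is this: the two compounds have the same atoms and bonds; at least one stereo element is drawn with a configuration in one of them and without one in the other: 1 of 1 stereo elements differ; a stereocentre at a saturated ring carbon is drawn without a configuration in compound 3 and S in compound 4. Two measured steps are available. The large one, a number 2.38 log units lower from compound 1 to compound 2 (beyond the scatter), came with 3,5-dimethyl-1,2-oxazol-4-yl in place of 2,5-dimethyl-1H-pyrrol-1-yl. The modest one, a number 0.39 log units higher from compound 2 to compound 3 (beyond the scatter), came with chloro in place of hydrogen. Both swapped one group for another, whereas here nothing leaves and nothing enters, so neither gives a size to carry over. With the same atoms and bonds in both compounds, no shift beyond the scatter is expected in this assay. The expected step, no change at the digits printed from compound 3 to compound 4 (within the scatter), stays within the scatter. Compound 4 is estimated at 1.96 with an expected range from 1.7 to 2.25.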

Compound 4, distribution coefficient: 1.93
For compound 4 the middle estimate is 0.03 log units above the measured one; low and high end bracket the measured number.
By their numbers in this assay, from the lowest: compound 2; then compounds 4 and 3 (each within the scatter of the next); then compound 1.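

In this assay, among these compounds, the earlier steps each exchanged one group for another and moved the number beyond the scatter, whereas this change gives a number 0.03 log units lower from compound 3 to compound 4 (within the scatter). At this saturated ring carbon, then, drawing the configuration as S leaves the reading in the same place, and this is the only change among those shown that touches no atom or bond. The pair is separated by nothing else: the fact that one of compounds 3 and 4 is drawn with a defined configuration and the other without, at the place where they differ.

The compounds shown leave open how a compound drawn as R at this carbon would read in this assay, set against the S form of compound 4. They also leave open how the reading would respond to a change in the side chain on this carbon, such as a longer chain ending in the carboxylic acid, or a primary amide in place of that acid.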